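The source may report more compounds than this note shows. Statements on the series, on what has been measured and on what is new or still open speak of the compounds shown alone.

Going by the values given here, in a physicochemical assay for solubility, in phosphate buffer, measured as kinetic solubility, at pH 7.4 (on this read-out lower numbers stand for lower solubility and higher numbers for higher solubility), compound 1 `Cc1cccc(Cl)c1-c1nc(CN2CCC(C(=O)NCCCN3CCCC(C)C3)CC2)c(C)o1` gives 52.6 ug/mL and serves as the only true number so far. Compound 2 `Cc1cccc(Cl)c1-c1nc(CN2CCC(C(=O)NCCCN3CCC(C)(C)CC3)CC2)c(C)o1` gives > 74 ug/mL in this assay and this is a limit of the assay, not a number. Compound 2 therefore sits at the limit of > 74 ug/mL in this assay, at which 1 of the 2 values shown sits, with no value of its own. Compound 3 `Cc1cccc(Cl)c1-c1nc(CN2CCC(C(=O)NCCCN3CCC(C(C)C)CC3)CC2)c(C)o1` carries 4-isopropylpiperidin-1-yl in place of 4,4-dimethylpiperidin-1-yl on a saturated chain carbon, three bonds along the chain from an amide-type nitrogen and the rest of the molecule is unchanged. Among the compounds with values here, the one measured step at this place is an at least 1.4-fold higher number from compound 1 to compound 2 (0.14 log units; that floor lies within the scatter) and it exchanges 3-methylpiperidin-1-yl for 4,4-dimethylpiperidin-1-yl. That step sets only a floor, so no step beyond the scatter can be expected in this assay in either direction. The nearest number remains compound 1 at 52.6 ug/mL as the anchor for the expectation. The expected step is an at least 1.2-fold lower number from compound 2 to compound 3 (0.09 log units; that floor lies within the scatter) as an estimate against a limit only. Compound 3 is estimated at 60 ug/mL within an expected range of 30 ug/mL to 85 ug/mL for this measurement.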

Compound 3, solubility: > 76 ug/mL
Compound 3: a limit, no number; the forecaster's own chance of this, stated with the estimate: 35%; at least 1.2-fold (0.10 log units) between middle value and limit.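

In this assay compound 3 gives > 76 ug/mL, which is a limit of the assay and not a number. Read against the one true number in the series, the change shows an at least 1.4-fold higher number from compound 1 to compound 3 (0.15 log units; that floor lies within the scatter), so this second replacement of 3-methylpiperidin-1-yl again yields only a floor, and that floor lies within the scatter; the step between the two limits cannot be read. Going by these compounds alone, on a saturated chain carbon, three bonds along the chain from an amide-type nitrogen, 4-isopropylpiperidin-1-yl with 9 heavy atoms therefore joins 4,4-dimethylpiperidin-1-yl with 8 as a second group that returns a limit, and compound 1 remains the only compound with a true number.

Still open, from the compounds shown here alone, is how compound 2 and compound 3 truly stand against each other and against compound 1, since neither has a number of its own. Also open, going by these compounds, is what a morpholin-4-yl group or a dimethylamino group would give at this place, or what a longer chain would give in place of the propyl link, in this assay.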